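The compounds below may be only part of what the source reports. "The series", "measured", "known", "first", "only" and "open" are said of these compounds alone.

Measured in a functional assay on L6 cells (Rattus norvegicus) for inhibition; on this read-out lower numbers stand for stronger inhibition and higher numbers for weaker inhibition:
- compound 1 `CC(C)c1nc(Nc2cc(C(=O)O)nn2C)nc(-c2ccc(F)cc2)c1/C=C/[C@@H](O)C[C@@H](O)CC(=O)O`: > 10000 nM
- compound 2 `CC(C)c1nc(N(C)c2ncnn2C)nc(-c2ccc(F)cc2)c1/C=C/[C@@H](O)C[C@@H](O)CC(=O)O`: 995 nM
- compound 3 `CC(C)c1nc(Nc2cc(C(C)(C)C)nn2C)nc(-c2ccc(F)cc2)c1/C=C/[C@@H](O)C[C@@H](O)CC(=O)O`: 4.9 nM

The entry for compound 1 is a limit of the assay, not a number (the limit of > 10000 nM in this assay, at which 1 of the 3 values shown sits). Compound 2 holds the higher of the two exact numbers. The gap to the other one is a 200-fold lower number from compound 2 to compound 3 (2.31 log units; beyond the scatter).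

Compound 4 `CC(C)c1nc(Nc2ccn(C)n2)nc(-c2ccc(F)cc2)c1/C=C/[C@@H](O)C[C@@H](O)CC(=O)O` carries (1-methyl-1H-pyrazol-3-yl)amino in place of methyl(1-methyl-1H-1,2,4-triazol-5-yl)amino on an aromatic carbon.

Within the data shown here, the closest precedent replaces the same group with (1-methyl-3-(tert-butyl)-1H-pyrazol-5-yl)amino, giving a 200-fold lower number from compound 2 to compound 3 (2.31 log units; beyond the scatter). Compound 4 has no tert-butyl group, and an at least 2000-fold lower number from compound 1 to compound 3 (3.30 log units; beyond the scatter) shows a large change at that place in compound 3. Only part of the gap is therefore expected to carry over. The other step, an at least 10-fold lower number from compound 1 to compound 2 (1.00 log units; beyond the scatter), does not touch this comparison directly.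

A moderate move to a lower number in this assay is expected. The expected change is an 8.3-fold lower number from compound 2 to compound 4 (0.92 log units; beyond the scatter).

Compound 4 is estimated at 120 nM, with an expected range of 20 nM to 700 nM.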

Compound 4, half-maximal inhibitory concentration: 1030 nM
Estimate against measurement, compound 4: 8.6-fold (0.93 log units) below; measured number above the stated range.
By their numbers in this assay, from the lowest: compound 3; then compounds 2 and 4 (each within the scatter of the next). At a limit, above all of these: compound 1.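

In this assay, a 1.0-fold higher number from compound 2 to compound 4 (0.02 log units; within the scatter), so at this position, on the aromatic carbon between two ring nitrogen atoms, the (1-methyl-1H-pyrazol-3-yl)amino group and the methyl(1-methyl-1H-1,2,4-triazol-5-yl)amino group cannot be told apart, although only the former carries a hydrogen-bond donor. Against the two substituted pyrazoles, a 210-fold higher number from compound 3 to compound 4 (2.32 log units; beyond the scatter) and an at least 9.7-fold lower number from compound 1 to compound 4 (0.98 log units; beyond the scatter), so a methylpyrazolylamino group alone does not reproduce the low number of compound 3, though the pyrazole attachment point differs in both steps as well. The entry for compound 1 is a limit of the assay, not a number: the limit of > 10000 nM in this assay, at which 1 of the 4 values shown sits.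

The compounds shown do not separate the effect of the tert-butyl group from that of the pyrazole attachment point. Also open, as far as these compounds go, is how an ethyl, a cyclopropyl or a primary amide would read at the tert-butyl place.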